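This account rests on a few compounds, and the source may have more. Where it says the series, first, only, none or still open, it means among the compounds named here.

Measured compounds in the series:

compound 1, `Cc1ccc(-c2nnc(NC(=O)/C=C/c3ccc(C(F)(F)F)cc3)s2)cc1`: 1.1 ug/mL
compound 2, `O=C(/C=C/c1ccccc1)Nc1nnc(-c2ccc(Cl)cc2)s1`: 1.42 ug/mL
compound 3, `COc1ccc(/C=C/C(=O)Nc2nnc(-c3ccc(Br)cc3)s2)cc1`: 1.13 ug/mL

All three share one core and differ in the substituent on each outer phenyl ring. In a functional assay on MCF7 cells (Homo sapiens) for antiproliferative activity, read by MTT assay, with a stated time of 48 h (on this read-out higher numbers stand for weaker inhibition and lower numbers for stronger inhibition), the three numbers sit close together: compound 3 has the second highest number of the three, its nearest neighbour being compound 1 and its furthest compound 2, and both gaps lie within the scatter of repeated measurements. No ordering among compounds 1, 2 and 3 can therefore be read from these numbers.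

Compound 4, `Cc1ccc(/C=C/C(=O)Nc2nnc(-c3ccc(Br)cc3)s2)cc1`, has not been measured. It differs from compound 3 in one place only:

methyl in place of methoxy on an aromatic carbon

The change, read one bond further out, is 4-methoxyphenyl to 4-methylphenyl, with the bromophenyl side of the core untouched. Within the data shown here, no pair of measured compounds shows this particular exchange, so no measured step guides it. Since compounds 1, 2 and 3 with different para substituents all land within the scatter of one another, the step from compound 3 to compound 4 is expected to stay within the scatter as well, with no direction favoured: a 1.1-fold higher number from compound 3 to compound 4 (0.03 log units; within the scatter). Compound 4 is estimated at 1.2 ug/mL, with a range from 0.6 ug/mL to 2.5 ug/mL.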

Compound 4, half-maximal inhibitory concentration: 1.32 ug/mL
Estimate against measurement, compound 4: 1.1-fold (0.04 log units) below; the measured number falls inside the stated range.
By their numbers in this assay, from the lowest: compounds 1, 3, 4 and 2 (each within the scatter of the next).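

In this assay, among these compounds, the exchange of methoxy for methyl on an aromatic carbon, para to a large group, gives a 1.2-fold higher number from compound 3 to compound 4 (0.07 log units; within the scatter) and is the first single-place step. With the bromophenyl side held fixed, the two groups cannot be told apart at this position, even though the oxygen and the hydrogen-bond acceptor of methoxy are absent from methyl. No measurement shown accounts for this outcome.

Going by these compounds, whether an amine, a carboxylic acid or a longer alkyl chain at this position would give a step beyond the scatter remains open. Also open, on these data alone, is whether the exchange of methoxy for methyl would read the same with chlorine or a methyl group in place of the bromine on the other phenyl ring.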